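The source may report more compounds than this note shows. Statements on the series, on what has been measured and on what is new or still open speak of the compounds shown alone.

Measured compounds:
compound 1 `Nc1ccc(Cl)cc1C1=NN(C(=O)C2CC2)CC1` — in an assay on isolated protein for inhibition of Nitric oxide synthase, inducible (Homo sapiens), with a stated time of 30 min, tested at 1 mM (a higher number here means more inhibition at the concentration tested (going by the name of the read-out), a lower number less inhibition), compound 1 gives 18.9%
compound 2 `CC(=O)N1CCC(c2ccccc2N)=N1` — in this assay compound 2 gives 7.73%

Only these two compounds have been measured. Compound 2 gives the lower of the two values in this assay, and compound 1 sits higher by a margin beyond the usual scatter of repeated runs. Compound 3 `CC(=O)N1CCC(c2cc(Cl)ccc2N)=N1` is compound 2 with a single change: chloro in place of hydrogen on an aromatic carbon. Going by the values given here, no pair of measured compounds differs in exactly one place, so there is no measured step that isolates this change. Compound 1 carries the same chloro group but also a different group on the amide nitrogen, and its value shows only what the two changes together bring. On that showing, the step in this assay from compound 2 to compound 3 is expected to be upward and of modest size, and it may well stay within the scatter. Compound 3 is estimated to give 14% in this assay, with a range from 4% to 26%. The expected step is a number 6.3 percentage points higher from compound 2 to compound 3 (within the scatter).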

Compound 3, a percentage reported as inhibition, at one concentration (the size of the read-out at that concentration, not a potency): 1.03%
For compound 3 the middle estimate is 13 percentage points above the measured one; measured number below the stated range.
By their numbers in this assay, from the lowest: compounds 3 and 2 (each within the scatter of the next); then compound 1.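

In this assay, chloro in place of hydrogen on the aromatic carbon para to the amino group gives a number 6.7 percentage points lower from compound 2 to compound 3 (within the scatter) and so, with methyl on the carbonyl carbon, brings no change that can be told apart from the scatter of repeated runs. With that chloro present on both sides, methyl in place of cyclopropyl on the carbonyl carbon gives a number 17.9 percentage points lower from compound 1 to compound 3 (beyond the scatter) as the first step here that isolates the carbonyl group, and it is the only single change among these compounds that lies beyond the scatter. Nothing measured here gives a reason for either step.

Going by these compounds, it remains open whether swapping cyclopropyl for methyl gives a step of similar size when hydrogen rather than chloro sits on the aromatic carbon, since the value of such a cyclopropyl compound is needed to compare the two settings. Also open, on these data alone, is how an ethyl group or a longer chain on the carbonyl carbon would compare with cyclopropyl and methyl, and whether fluoro or methoxy in the chloro position would read any differently from hydrogen.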